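The source may report more compounds than this note shows. Statements on the series, on what has been measured and on what is new or still open speak of the compounds shown alone.

Measured so far:
Compound 1, `CCCCN(CC)c1nc(C)nc2c1NC(=O)CN2c1ccc(C#N)cc1C`, gives 573 nM.
Compound 2, `CCCCN(CC)c1nc(C)nc2c1NCCN2c1ccc(C#N)cc1C`, gives 102 nM.
Compound 3, `CCCCN(CC)c1nc(C)nc2c1NC(=O)CN2c1ccc(C(C)=O)cc1C`, gives 713 nM.

All three numbers come from an assay on frontal cortex for displacement of a labelled ligand from corticotropin-releasing factor receptor 1 (Rattus norvegicus); on this read-out higher numbers stand for weaker inhibition and lower numbers for stronger inhibition. Compound 1 and compound 3 share one core and differ in a single place: acetyl in place of cyano on an aromatic carbon. That change gave a 1.2-fold higher number from compound 1 to compound 3 (0.09 log units; within the scatter), so on this core the two groups are not told apart. Compound 2 has the lowest number of the three, and its gap to compound 1 and to compound 3 lies beyond the usual scatter. How the core of compound 2 differs from the core of compound 1 is not broken down here.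

Compound 4, `CCCCN(CC)c1nc(C)nc2c1NCCN2c1ccc(C(C)=O)cc1C`, has not yet been measured. It is built from compound 2 by the same change already seen between compound 1 and compound 3: acetyl in place of cyano on an aromatic carbon. The surroundings of the change are the same in both pairs, so it is the same change. Because a 1.2-fold higher number from compound 1 to compound 3 (0.09 log units; within the scatter), the step from compound 2 to compound 4 is expected to be small as well, about a 1.2-fold higher number from compound 2 to compound 4 (0.07 log units; within the scatter). Compound 4 is therefore estimated at 120 nM, expected to lie between 60 nM and 250 nM.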

Compound 4, half-maximal inhibitory concentration: 172 nM
Beside the measured number, compound 4's estimate is 1.4-fold (0.16 log units) below it; measured number inside the range.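

In this assay, putting acetyl in place of cyano on the aromatic carbon gave a 1.7-fold higher number from compound 2 to compound 4 (0.23 log units; within the scatter), so on the core of compound 2, as on the core of compound 1, the two groups cannot be told apart. Set side by side, the change behaves alike on both cores, and the two steps do not differ by more than their scatter: the same change on two cores in this assay, a 1.2-fold higher number (0.09 log units; within the scatter) from compound 1 to compound 3 and a 1.7-fold higher number (0.23 log units; within the scatter) from compound 2 to compound 4, 1.4-fold (0.13 log units) apart, within the scatter of two such steps. This supports carrying the change between these two cores only, and as neither step can be told from the scatter, it does not show that a change with a large effect would carry over in the same way, nor does it explain why the two groups score alike.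

Still open, going by these compounds, is whether a carboxylic acid, an amine or a longer acyl chain in place of cyano would separate from these two groups on either core. Also open, on these data alone, is whether chlorine in place of the methyl group would alter the picture.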